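The source may hold more compounds than are shown below. What is called first, only, known or untested is meant among the compounds shown, and "the series" means these compounds.

Compound 1 `COc1ccc(-c2cc(NNC(=O)Nc3cc(Cl)nc(OC(C)C)c3)nc3c2cnn3C)cc1`: 47100 nM
Compound 2 `COc1ccc(-c2cc(NNC(=O)Nc3cc(Br)nc(Br)c3)nc3c2cnn3C)cc1`: 54100 nM
Compound 3 `COc1cc(NC(=O)NNc2cc(-c3ccc(F)cc3)c3cnn(C)c3n2)cc(Cl)n1`: 24100 nM

These three compounds were measured in a functional assay on SW620/5-FU cells (Homo sapiens) for cytotoxicity, read by MTT assay, with a stated time of 48 h, in the presence of a further agent that is not named here; a lower number here means that less compound is needed, a higher number that more compound is needed for the effect. Compound 2, at 54100 nM, has the highest number of the three, although it stands within the scatter of compound 1. Compound 3 shows a lower number, 24100 nM.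

Compound 4 `CCCOc1cc(NC(=O)NNc2cc(-c3ccc(OC)cc3)c3cnn(C)c3n2)cc(Cl)n1` differs from compound 2 in one place, with 2-chloro-6-propoxypyridin-4-yl in place of 2,6-dibromopyridin-4-yl on an amide-type nitrogen. Among the compounds with values here, one measured step bears on this change. It joins the same 2,6-dibromopyridin-4-yl to 2-chloro-6-isopropoxypyridin-4-yl, which carries the branched form of the chain: a 1.1-fold higher number from compound 1 to compound 2 (0.06 log units; within the scatter). Within the data shown here, compound 3 differs from compound 2 in more than one place and offers no clean step.

In this assay, no change beyond the scatter is therefore expected. The expected change is a 1.2-fold lower number from compound 2 to compound 4 (0.06 log units; within the scatter). For compound 4 the estimated value is 47000 nM, with an expected range of 24000 nM to 92000 nM.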

Compound 4, half-maximal effective concentration: 37200 nM
Estimate against measurement, compound 4: 1.3-fold (0.10 log units) above; the range from low to high includes it.
By their numbers in this assay, from the lowest: compounds 3, 4, 1 and 2 (each within the scatter of the next, the first and the last beyond it).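

In this assay, 2-chloro-6-propoxypyridin-4-yl in place of 2,6-dibromopyridin-4-yl on the amide-type nitrogen gives a 1.5-fold lower number from compound 2 to compound 4 (0.16 log units; within the scatter), so a second exchange at this place also stays within the scatter. The earlier compounds shown here held only the branched chain, and the straight chain now adds a direct comparison: propyl in place of isopropyl on the oxygen gives a 1.3-fold lower number from compound 1 to compound 4 (0.10 log units; within the scatter), so these two chains cannot be told apart here. No measurement shown accounts for these small steps.

Going by these compounds, whether a longer chain, such as butoxy, or an amine in place of the propoxy group would move the number beyond the scatter remains open. On these data alone, it is also open whether any group at this place would bring a clear change from the values seen so far.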